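A Protecting Group Removed: Expected Gain in Solubility

A few compounds are considered here, and "the series" means these few. Any claim that something is new, unique, unknown or untested is made for them only; others in the source may bear on it.

Compound 1 `CN1CCN(c2cnc3[nH]cc(-c4cccc(C#N)c4)c3c2)CC1` and compound 2 `CC(C)(C)OC(=O)N1CCN(c2cnc3[nH]cc(-c4cccc(C#N)c4)c3c2)CC1` share one core; compound 2 carries a tert-butoxycarbonyl group where compound 1 carries a methyl (methyl in place of tert-butoxycarbonyl on an amine nitrogen in a ring). In a physicochemical assay for solubility, read by LC-MS, in phosphate buffer, measured as thermodynamic solubility, with a stated time of 24 h, at pH 7.4 (a higher number here means a more soluble compound, a lower number a less soluble compound), compound 2 gives 12000 nM and compound 1 gives 230000 nM, a step of a 19-fold higher number from compound 2 to compound 1 (1.28 log units; beyond the scatter). Compound 3 `CC(C)(C)OC(=O)N1CCC(n2cc(-c3cnc4[nH]cc(-c5cccc(C#N)c5)c4c3)cn2)CC1` is built on another core, and the difference between the two cores is not broken down here; in this assay compound 3 gives 1800 nM. Compound 4 `CN1CCC(n2cc(-c3cnc4[nH]cc(-c5cccc(C#N)c5)c4c3)cn2)CC1` makes the same kind of change on compound 3 (methyl in place of tert-butoxycarbonyl on an amine nitrogen in a ring), though here the six-membered non-aromatic ring has 1 nitrogen rather than 2 nitrogen. Because the same kind of change gave a 19-fold higher number from compound 2 to compound 1 (1.28 log units; beyond the scatter), the step is expected to be about a 14-fold higher number from compound 3 to compound 4 (1.14 log units; beyond the scatter). Compound 4 is therefore estimated at 25000 nM, most likely between 6000 nM and 100000 nM.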

Compound 4, solubility: 3800 nM
The estimate for compound 4 lay 6.6-fold (0.82 log units) above the measured number; measured number outside the range, below it.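

In this assay, putting methyl in place of tert-butoxycarbonyl raises the number on both cores, giving a 2.1-fold higher number from compound 3 to compound 4 (0.32 log units; beyond the scatter) on the second core against a 19-fold higher number from compound 2 to compound 1 (1.28 log units; beyond the scatter) on the first. Across these two pairs, then, the direction of the change carried from one core to the other, but its size did not, and two pairs cannot show how the change would behave on any further core. No measurement given here explains why the step is smaller on the second core.

As far as these compounds go, it remains open how other groups on the same amine nitrogen, such as an ethyl or an acetyl, would compare on each core. The same goes for a plain hydrogen there.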